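The source may report more compounds than this note shows. Statements on the series, on what has been measured and on what is new or still open speak of the compounds shown alone.

Measured so far:
compound 1 `Cc1[nH]c2ccccc2c1C=C(C#N)C#N`, 56000 nM
compound 2 `N#CC(C#N)=Cc1c[nH]c2ccccc12`, 36000 nM
compound 3 `Cc1[nH]c2ccccc2c1/C=C(\C#N)S(C)(=O)=O`, for which the assay gives only a limit: > 100000 nM

All three were tested in a functional assay on MT4 cells (Homo sapiens) for antiproliferative activity, read by MTT assay, with a stated time of 96 h; a lower number here means that less compound is needed, a higher number that more compound is needed for the effect. In this assay compound 1 gives 56000 nM and compound 2 gives 36000 nM. The change from compound 1 to compound 2 is hydrogen in place of methyl on an aromatic carbon and it made a 1.6-fold lower number from compound 1 to compound 2 (0.19 log units; within the scatter). For compound 3 the assay reports a limit rather than a number, (the limit of > 100000 nM in this assay, at which 1 of the 3 values shown sits). How the core of compound 3 differs from the core of compound 1 is not broken down here.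

Compound 4 `CS(=O)(=O)/C(C#N)=C/c1c[nH]c2ccccc12` has not yet been measured. It differs from compound 3 by hydrogen in place of methyl on an aromatic carbon. Going by the values given here, this is the same kind of change as the one from compound 1 to compound 2, but the surroundings differ: in compound 1 the carbon is next to the ring atom that bears a group of 6 heavy atoms, in compound 3 next to the ring atom that bears a group of 8 heavy atoms. Because the earlier step of a 1.6-fold lower number from compound 1 to compound 2 (0.19 log units; within the scatter) stayed within the scatter, compound 4 is expected to show a step of similar size, a step that the limit leaves unreadable from compound 3 to compound 4. Compound 4 is therefore estimated at 150000 nM, with a likely range from 50000 nM to 500000 nM, and may well again be reported only as a limit.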

Compound 4, half-maximal effective concentration: > 100000 nM
Compound 4: no number, only a limit; the forecaster's own chance of this, stated with the estimate: 65%; the middle value is on the limit's open side.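

In this assay, going by these compounds alone, compound 3 and compound 4 are each reported only as a limit, not as a number, so no step between them can be read: the limit of > 100000 nM in this assay, at which 2 of the 4 values shown sit. The compounds shown leave open whether hydrogen in place of methyl on an aromatic carbon changes the number for compound 3 as little as it does for compound 1.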